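A few compounds are considered here, and "the series" means these few. Any claim that something is new, unique, unknown or untested is made for them only; others in the source may bear on it.

Values measured in a functional assay on Rec1 cells (Homo sapiens) for inhibition, read by luminescence and CellTiter-Glo, with a stated time of 72 h (a higher number here means a weaker inhibitor, a lower number a stronger inhibitor), are as follows.

- Compound 1 `O=C(CCl)N1CCCC(n2nc(-c3ccc(Oc4ccccc4)cc3)cc2CO)C1` gives 400 nM
- Compound 2 `C/C=C/C(=O)N1CCCC(n2nc(-c3ccc(Oc4ccccc4)cc3)cc2C(=O)OCC)C1` gives 5100 nM
- Compound 3 `C/C=C/C(=O)N1CCCC(n2nc(-c3ccc(Oc4ccccc4)cc3)cc2C(=O)O)C1` gives 31000 nM

Compound 3 has the highest number of the three, which makes it the weakest inhibitor so far. Compound 2 sits closest to it, and compound 1 is furthest away.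

The next compound, compound 4 `C/C=C/C(=O)N1CCCC(n2nc(-c3ccc(Oc4ccccc4)cc3)cc2CO)C1`, matches compound 3 except for one group, with hydroxymethyl in place of carboxy on an aromatic carbon. One measured step involves the same carbon, where the ethyl on the ester is replaced by hydrogen. That step, a 6.1-fold higher number from compound 2 to compound 3 (0.78 log units; beyond the scatter), is modest but beyond the scatter, and it shows that compound 3 lost strength relative to its ester. Compound 1 already carries hydroxymethyl on this carbon and gives 400 nM in this assay, which points to a lower number. However, compound 1 also differs from compound 4 in its amide group, and no measured pair separates these two differences. The expected change in this assay is therefore a 10-fold lower number from compound 3 to compound 4 (1.01 log units; beyond the scatter), towards a stronger inhibitor and somewhat larger than the modest step seen with the ester. For compound 4 the estimated value is 3000 nM, with an expected range from 700 nM to 12000 nM.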

Compound 4, half-maximal inhibitory concentration: 27200 nM
Estimate against measurement, compound 4: 9.1-fold (0.96 log units) below; the whole stated range lies below it.
By their numbers in this assay, from the lowest: compound 1; then compound 2; then compounds 4 and 3 (each within the scatter of the next).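

Carboxy and hydroxymethyl on this aromatic carbon cannot be told apart in this assay, with a 1.1-fold lower number from compound 3 to compound 4 (0.06 log units; within the scatter) as the whole difference between them, so hydroxymethyl does not by itself bring the number down in this series. Ethoxycarbonyl on the same carbon stands apart from hydroxymethyl, with a 5.3-fold higher number from compound 2 to compound 4 (0.73 log units; beyond the scatter) in this comparison, although that step is only modest. With hydroxymethyl held fixed, the step at the other end of the molecule is much larger: prop-1-en-1-yl in place of chloromethyl on a carbonyl carbon gives a 68-fold higher number from compound 1 to compound 4 (1.83 log units; beyond the scatter), which shows that the low number of compound 1 goes with its chloromethyl amide rather than with hydroxymethyl. No measurement here explains why either change has the size it does.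

The compounds shown leave open whether carboxy, hydroxymethyl and ethoxycarbonyl would keep the same relationship if all three carried chloromethyl on the carbonyl carbon. They also leave open how a different group on the aromatic carbon, such as aminomethyl or a primary amide, would compare with ethoxycarbonyl.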